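A few compounds are considered here, and "the series" means these few. Any claim that something is new, unique, unknown or untested is made for them only; others in the source may bear on it.

Within the data shown here, compound 2 `COc1nc(-c2cccnc2)cc(-c2ccc(F)cc2)c1C#N` is one of two compounds so far measured in an assay on isolated protein for inhibition of sulfide:quinone oxidoreductase, mitochondrial (Homo sapiens); on this read-out lower numbers stand for stronger inhibition and higher numbers for weaker inhibition. On that read-out compound 2 gives 213 nM, the higher of the two numbers. Among the measured compounds shown here, its only neighbour is compound 1 `COc1nc(-c2ccccc2)cc(-c2ccc(F)cc2)c1C#N`, which in this assay gives 25 nM. The two differ in one place, pyridin-3-yl in compound 2 standing where compound 1 carries phenyl on an aromatic carbon, and that single change gave an 8.5-fold higher number from compound 1 to compound 2 (0.93 log units; beyond the scatter).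

Compound 3 `COc1nc(-c2ncccc2C)cc(-c2ccc(F)cc2)c1C#N` has not yet been measured in this assay. It differs from compound 2 in that same place only: 3-methylpyridin-2-yl in place of pyridin-3-yl on an aromatic carbon. For the measured compounds named here, the one measured step that bears on it, an 8.5-fold higher number from compound 1 to compound 2 (0.93 log units; beyond the scatter), shows that exchanging phenyl for a pyridine ring weakened inhibition. Here, though, the ring remains a pyridine, with a methyl added, so that step gives no firm direction; a step of similar size either way is possible, as is none beyond the scatter. The expected value for compound 3 is therefore 180 nM, within 50 nM to 650 nM, which amounts to an estimated 1.2-fold lower number from compound 2 to compound 3 (0.07 log units; within the scatter).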

Compound 3, half-maximal inhibitory concentration: 8.7 nM
Beside the measured number, compound 3's estimate is 21-fold (1.32 log units) above it; measured number below the stated range.
By their numbers in this assay, from the lowest: compound 3; then compound 1; then compound 2.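

In this assay this position does not simply disfavour a pyridine ring: the change to 3-methylpyridin-2-yl gave a 24-fold lower number from compound 2 to compound 3 (1.39 log units; beyond the scatter) and so recovered everything lost with pyridin-3-yl. It went further still, with a 2.9-fold lower number from compound 1 to compound 3 (0.46 log units; beyond the scatter) and the phenyl ring left behind, so a pyridine here can go with either weaker or stronger inhibition than phenyl, depending on which pyridine it is. These numbers alone do not explain this reversal. No structural or other supporting measurement is available.

The step from compound 2 to compound 3 changes two things at once, the point at which the pyridine ring is attached and the added methyl, so the compounds shown cannot divide the gain between them. A plain pyridin-2-yl ring would separate those two parts, while an ethyl group or an amine in place of the methyl would show how much this one spot on the ring accepts.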